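The source may report more compounds than this note shows. Statements on the series, on what has been measured and on what is new or still open speak of the compounds shown alone.

The series shares one core, carried here by compound 1 `COC(=O)c1c(Nc2ccc(C)cc2)sc(C(=O)c2ccc(OC)cc2)c1C`, compound 2 `COC(=O)c1c(Nc2ccc(F)cc2)sc(C(=O)c2ccc(OC)cc2)c1C`, compound 3 `COc1ccc(C(=O)c2sc(Nc3ccc(C)cc3)c(C(=O)O)c2C)cc1` and the unmeasured compound 4 `COc1ccc(C(=O)c2sc(Nc3ccc(Cl)cc3)c(C(=O)O)c2C)cc1`. In a functional assay, with a stated time of 150 min, tested at 20 ug/mL (a lower number here means a weaker effect, a higher number a stronger effect of the compound at the concentration tested), compound 1 gives "not active" (no number reported). In this assay compound 2 gives 18.2%. In this assay compound 3 gives "not active" (no number reported), so no single number stands for it, and one further compound of the set likewise has no number. Going by the values given here, no pair among the measured compounds differs in only one place, so no step between measured values can be drawn.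

Compound 4 is reached from compound 3 by a change counted as chloro in place of methyl on an aromatic carbon. Among the measured compounds, a halogen at this ring appears only in compound 2, which carries a number, while the two compounds bearing methyl there, compound 1 and compound 3, carry none. On that basis a modest rise in this assay from compound 3 to compound 4 is expected, though compound 3 starts from no number, and the rise might not exceed the scatter. Compound 4 is therefore estimated at 15%, with a range from 0% to 35%, and it may well again be reported without a number.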

Compound 4, a percentage reported as activity, at one concentration (the size of the read-out at that concentration, not a potency): "not active" (no number reported)
For compound 4 the study gives words and no number, and the estimate cannot be compared.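

In this assay compound 3 gives "not active" (no number reported) and compound 4 gives "not active" (no number reported) with no number on either side, and no step can be read between them. Nothing given here bears on this result. The compounds shown leave open whether chloro in place of methyl on this ring changes the read-out at all.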